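The source may report more compounds than this note shows. Statements on the series, on what has been measured and on what is new or still open speak of the compounds shown alone.

Measured compounds:
Compound 1 `CC(=O)N[C@@H]1CCC[C@H](C(=O)Nc2cc(-c3cnn4c3CCC4)c(Cl)cn2)C1` gives 72 uL/min in an ADME assay on cells (Hepatocyte, Rattus norvegicus) for metabolic stability, using equilibrium dialysis; on this read-out higher numbers stand for fast clearance and lower numbers for slow clearance.
Compound 2 `CC(=O)N[C@@H]1CCC[C@H](C(=O)Nc2cc(-c3cnn4c3CC(C)(C)C4)ccn2)C1` gives 45 uL/min in this assay.

For the measured compounds named here, compound 2 has the lowest of the two numbers so far. Going by the values given here, the only other measured compound is compound 1, whose number is higher, yet the gap between the two lies within the usual scatter of repeated measurements, so the two cannot be told apart with confidence. The not yet measured compound 3 `CC(=O)N[C@@H]1CCC[C@H](C(=O)Nc2cc(-c3cnn4c3CC(C)(C)C4)c(C#N)cn2)C1` shares the core of compound 2 and differs from it in one place: cyano in place of hydrogen on an aromatic carbon. Among the compounds with values here, no step between two measured compounds tells what this change does on its own. With no such comparison at hand, the expected step from compound 2 to compound 3 in this assay is a 1.1-fold lower number from compound 2 to compound 3 (0.05 log units; within the scatter), small and not beyond the scatter. Compound 3 is therefore estimated at 40 uL/min, with a range from 20 uL/min to 80 uL/min.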

Compound 3, intrinsic clearance in a liver preparation (reported as CLH), per the amount of preparation that the assay uses in the Hepatocyte assay: 47 uL/min
The estimate for compound 3 lay 1.2-fold (0.07 log units) below the measured number; the measured number falls inside the stated range.
By their numbers in the Hepatocyte assay, from the lowest: compounds 2, 3 and 1 (each within the scatter of the next).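

In the Hepatocyte assay the step is a 1.0-fold higher number from compound 2 to compound 3 (0.02 log units; within the scatter), so cyano in place of hydrogen on this aromatic carbon, ortho to a large group, does not separate the two compounds on clearance. In a physicochemical assay for solubility, in phosphate buffer, at pH 7.4 (a higher number here means a more soluble compound, a lower number a less soluble compound), compound 2 gives 970000 nM and compound 3 gives 380000 nM, which brings out a difference that clearance alone did not show. At this position, then, the nitrile leaves clearance unresolved but comes with a real loss of solubility in the physicochemical assay: the measured solubility of compound 2, 970000 nM, and of compound 3, 380000 nM, a 2.6-fold lower number (0.41 log units; beyond the scatter)

Going by these compounds, this rests on a single pair of compounds, so it remains open whether the same change would act alike on another core. On these data alone, it is also open whether a different group on this carbon, such as an amine or a methoxy group, would keep clearance in the same range with less loss of solubility.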